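Trifluoromethyl in Place of Ethyl: What to Expect for Compound 4

The source may hold more compounds than are shown below. What is called first, only, known or untested is meant among the compounds shown, and "the series" means these compounds.

In an ADME assay on the whole organism with Oryza sativa as the target, tested at 0.1 uM (on this read-out lower numbers stand for a stronger effect and higher numbers for a weaker effect at the one concentration tested), the three measured compounds give the following numbers:

Compound 1, `CCc1ccc(NC(=O)N[C@H](C)c2ccccc2)cc1`: 95%
Compound 2, `CCc1ccc(NC(=O)N[C@@H](C)c2ccccc2)cc1`: 99%
Compound 3, `CCCCc1ccc(NC(=O)N[C@H](C)c2ccccc2)cc1`: 100%

Compound 2 stands second highest of these three numbers; its nearest neighbour is compound 3, one point higher and within the scatter, and its furthest is compound 1, four points lower and also within the scatter. Compounds 1 and 2 differ only in the configuration as drawn (the fact that compounds 1 and 2 differ only in the configuration as drawn), and the step of a number 4 percentage points higher from compound 1 to compound 2 (within the scatter) stays within the scatter. Within the data shown here, the step of a number 5 percentage points higher from compound 1 to compound 3 (within the scatter), the only measured change of a substituent on the aromatic ring, likewise stays within the scatter.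

Compound 4, `C[C@H](NC(=O)Nc1ccc(C(F)(F)F)cc1)c1ccccc1`, is still to be measured. It differs from compound 2 as follows: trifluoromethyl in place of ethyl on an aromatic carbon. Among the measured compounds shown here, no measured step exchanges ethyl for trifluoromethyl, so the expectation rests on the fact that neither measured change moved the read-out beyond the scatter, with all three numbers sitting close to the top of the scale.

The step of a number 2 percentage points lower from compound 2 to compound 4 (within the scatter) is therefore expected to be no larger than the scatter. Compound 4 is estimated to give 97%, with a range from 88% to 100%.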

Compound 4, a percentage reported as activity, at one concentration (the size of the read-out at that concentration, not a potency): 94%
Compound 4: middle estimate off by 3 percentage points, on the high side, and the stated range covers the measured number.
By their numbers in this assay, from the lowest: compounds 4, 1, 2 and 3 (each within the scatter of the next).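

On the aromatic carbon para to a large group, the exchange of ethyl for trifluoromethyl gives, in this assay, a number 5 percentage points lower from compound 2 to compound 4 (within the scatter), so the read-out does not separate these two groups at this place. The earlier compounds had shown only a change within an all-carbon chain at this position, a number 5 percentage points higher from compound 1 to compound 3 (within the scatter); compound 4 adds a group that brings in fluorine and has 4 heavy atoms where ethyl has 2, and this step also stays within the scatter. Nothing in the information at hand accounts for this outcome or says what either group contributes here.

On these data alone, all four compounds stay close to the top of the scale at the one concentration tested, so it remains open whether any group on this aromatic carbon can move the read-out beyond the scatter, and a single concentration gives no potency with which to rank them. As far as these compounds go, how an amine, a carboxylic acid or a longer chain would read at this place remains open, as does whether the configuration as drawn counts for anything once trifluoromethyl is present.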